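The compounds below may be only part of what the source reports. "The series", "measured", "known", "first", "only" and "open" are said of these compounds alone.

Of the compounds shown here, two have been measured in a functional assay on MCF7 cells (Homo sapiens) for cytotoxicity, read by sulforhodamine B assay, with a stated time of 72 h (on this read-out lower numbers stand for stronger inhibition and higher numbers for weaker inhibition), so far. Compound 1, `CC(=O)OC[C@H]1O[C@@H](n2cc(COC3=CC(=O)c4ccccc4C3=O)nn2)[C@H](OC(C)=O)[C@@H](OC(C)=O)[C@@H]1OC(C)=O`, gives 3330 nM in this assay. Compound 2, `CC(=O)OC[C@H]1O[C@@H](n2cc(COC3=CC(=O)c4ccccc4C3=O)nn2)[C@H](OC(C)=O)[C@@H](OC(C)=O)[C@H]1OC(C)=O`, gives 4220 nM in this assay. For the measured compounds named here, these two share every atom and bond and differ only in how one stereocentre on a saturated ring carbon is drawn, and the step of a 1.3-fold higher number from compound 1 to compound 2 (0.10 log units; within the scatter) is the only measured step available. That step says something about the fact that compounds 1 and 2 differ only in the configuration as drawn and nothing else. Compound 1 therefore stands as one of two numbers that sit within the scatter of each other, with no measured order between them.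

Compound 3, `CC(=O)N[C@@H]1[C@@H](OC(C)=O)[C@H](OC(C)=O)[C@@H](COC(C)=O)O[C@H]1n1cc(COC2=CC(=O)c3ccccc3C2=O)nn1`, is the next compound to be measured. It differs from compound 1 by acetamido in place of acetoxy on a saturated ring carbon. Going by the values given here, no measured step involves an exchange of a whole group, so nothing measured bears directly on this change, and the only measured step, which was within the scatter, gives no reason to expect a shift in either direction. Compound 3 is therefore expected to give about 3500 nM in this assay, with a range from 1400 nM to 9000 nM, an expected step of a 1.1-fold higher number from compound 1 to compound 3 (0.02 log units; within the scatter) that stays within the scatter.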

Compound 3, half-maximal inhibitory concentration: 28900 nM
Beside the measured number, compound 3's estimate is 8.3-fold (0.92 log units) below it, outside the stated range (above it).
By their numbers in this assay, from the lowest: compounds 1 and 2 (each within the scatter of the next); then compound 3.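

For the compounds shown here, putting acetamido in place of acetoxy on this saturated ring carbon gives an 8.7-fold higher number from compound 1 to compound 3 (0.94 log units; beyond the scatter) in this assay, the first step in this set that lies beyond the scatter, and it points to weaker inhibition. Going by these compounds alone, the only earlier step, a 1.3-fold higher number from compound 1 to compound 2 (0.10 log units; within the scatter), changed just the configuration as drawn at one stereocentre, whereas this change swaps one group for another of the same heavy-atom count, with one hydrogen-bond donor entering and one hydrogen-bond acceptor fewer, so the ring substituent here matters to the read-out in a way the earlier pair could not reveal. Why the number rises remains unexplained, as nothing available bears on this exchange of groups.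

A single exchange at a single place cannot separate the amide hydrogen from anything else that differs between acetamido and acetoxy. From the compounds shown here alone, an amine or a hydroxyl on this same ring carbon, or a longer chain such as propionamido in place of acetamido, would show whether the number follows the amide itself, and whether the same exchange matters elsewhere on the ring also remains open.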